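One Methyl Group, One Open Question

A few compounds are considered here, and "the series" means these few. Any claim that something is new, unique, unknown or untested is made for them only; others in the source may bear on it.

Of the compounds shown here, three built on a shared core have been tested in a functional assay on K562/A02 cells (Homo sapiens) for antiproliferative activity, read by MTT assay; a lower number here means a stronger inhibitor, a higher number a weaker inhibitor. Compound 1 `O=C(CCCCCNC(=S)NN=C(c1ccccn1)c1ccccn1)NO` gives 2180 nM, compound 2 `O=C(CCCCCNC(=S)N/N=C(\c1ccccc1)c1ccccn1)NO` gives 2030 nM, and compound 3 `O=C(CCCCCNC(=S)NN=C(c1ccccc1)c1ccccc1)NO` gives 3640 nM. Compound 3 shows the highest of the three numbers, yet its gaps to compound 1 and to compound 2 both fall within the scatter that repeated measurements of this kind usually show, so the three cannot be separated on potency.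

Compound 4 `Cc1ccc(/C(=N/NC(=S)NCCCCCC(=O)NO)c2ccccc2)cc1` has not yet been measured. It differs from compound 3 in one place: methyl in place of hydrogen on an aromatic carbon. For the measured compounds named here, no pair of measured compounds shows a comparable change, so there is no measured step to lean on. The change adds only a methyl group, and the three measured compounds already sit close together. The step in this assay is therefore expected to be small, a 1.1-fold lower number from compound 3 to compound 4 (0.06 log units; within the scatter), reaching no further than the scatter in either direction. Compound 4 is expected to give about 3200 nM in this assay, with a plausible range from 1300 nM to 8000 nM.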

Compound 4, half-maximal inhibitory concentration: 3150 nM
Estimate against measurement, compound 4: 1.0-fold (0.01 log units) above, within the range that was stated.
By their numbers in this assay, from the lowest: compounds 2, 1, 4 and 3 (each within the scatter of the next).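

In this assay the step of a 1.2-fold lower number from compound 3 to compound 4 (0.06 log units; within the scatter) lies within the scatter, so methyl in place of hydrogen on this aromatic carbon, para to a large group, does not measurably shift the result. The step of a 1.6-fold higher number from compound 2 to compound 4 (0.19 log units; within the scatter) also lies within the scatter, which means that 4-methylphenyl in place of pyridin-2-yl on the carbon with a double bond to nitrogen cannot be told apart from the original on potency either. No measurement on hand offers an explanation for how small these steps are.

As far as these compounds go, whether this position tolerates any group is still open, since a single methyl is a narrow test. A carboxylic acid, an amine or a longer chain at the same place could yet move the number beyond the scatter, in either direction.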